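Trimming the Alkyne Chain: What to Expect for Compound 3

The source may hold more compounds than are shown below. What is called first, only, known or untested is meant among the compounds shown, and "the series" means these compounds.

Compound 1, `CC(=O)Nc1nc(-c2cccc(NS(=O)(=O)c3ccc(C#C[Si](C)(C)C)cc3)c2)cs1`: 4.2%
Compound 2, `CCCCCCC#Cc1cccc(S(=O)(=O)Nc2cccc(-c3csc(NC(C)=O)n3)c2)c1`: 1.2%

In a functional assay on A-375 cells (Homo sapiens) for antiproliferative activity, read by trypan blue exclusion, with a stated time of 48 h, tested at 5 uM (a higher number here means a weaker effect of the compound at the concentration tested, a lower number a stronger effect), compound 1 gives 4.2%, and compound 2 gives 1.2%. Compound 2 sits at the bottom of these two numbers, yet the gap to compound 1 lies within the scatter, so neither counts as stronger. Compound 3, `C#Cc1cccc(S(=O)(=O)Nc2cccc(-c3csc(NC(C)=O)n3)c2)c1`, is not yet measured. It differs from compound 2 in one place: hydrogen in place of hexyl on a triple-bonded carbon. Among the measured compounds shown here, no measured pair shows a change of this kind, so the step is only an expectation, estimated as a number 13.8 percentage points higher from compound 2 to compound 3 (beyond the scatter), with a rise beyond the scatter somewhat more likely than none. Compound 3 is expected to give 15%, within 1% to 50%.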

Compound 3, a percentage reported as activity, at one concentration (the size of the read-out at that concentration, not a potency): 29%
Beside the measured number, compound 3's estimate is 14 percentage points below it, and the stated range covers the measured number.
By their numbers in this assay, from the lowest: compounds 2 and 1 (each within the scatter of the next); then compound 3.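

In this assay, swapping the hexyl on the triple-bonded carbon for hydrogen, which turns oct-1-yn-1-yl into ethynyl, gives a number 27.8 percentage points higher from compound 2 to compound 3 (beyond the scatter) and so a weaker effect at the concentration tested. Among the compounds shown here, this is the first sign that the group on this carbon matters, as the bare ethynyl does not keep the effect seen with the hexyl in place. Nothing available explains this step.

Open, from the compounds shown here alone, is how much chain is needed: whether a methyl, a propyl or a butyl on this carbon would restore the effect. Also open, going by these compounds, is whether an amine at the chain end would be tolerated.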